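Swapping the carboxyphenyl group for a hydroxymethylphenyl group

The compounds below may be only part of what the source reports. "The series", "measured", "known", "first", "only" and "open" are said of these compounds alone.

Three ureas sharing one core have been measured in an assay on microsomes for inhibition of acyl-CoA:cholesterol acyltransferase (Oryctolagus cuniculus); a lower number here means a stronger inhibitor, a higher number a weaker inhibitor. Compound 1 `CC(C)c1cccc(C(C)C)c1NC(=O)NCC1(c2ccc(CC(C)(C)C)cc2)CCCC1` gives 159 nM. Compound 2 `CC(C)c1cccc(C(C)C)c1NC(=O)NCC1(c2ccc(N)cc2)CCCC1` gives 29 nM, and compound 3 `CC(C)c1cccc(C(C)C)c1NC(=O)NCC1(c2ccc(C(=O)O)cc2)CCCC1` gives 3100 nM, the highest number of the three. The two steps leading to it were both large: a 19-fold higher number from compound 1 to compound 3 (1.29 log units; beyond the scatter) and a 110-fold higher number from compound 2 to compound 3 (2.03 log units; beyond the scatter), so the carboxy group sits on the weak side of this small set.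

Compound 4 `CC(C)c1cccc(C(C)C)c1NC(=O)NCC1(c2cccc(CO)c2)CCCC1` differs from compound 3 in one place: 3-(hydroxymethyl)phenyl in place of 4-carboxyphenyl on a saturated ring carbon. Among the measured compounds shown here, no measured pair covers this exact exchange, and the shift of the substituent around the ring has no precedent here. What does bear on it is that both changes which brought the carboxy group in raised the number strongly, while compound 1 and compound 2 without it stand far lower. Taking the carboxy group out again is therefore expected to lower the number in this assay, by a 10-fold lower number from compound 3 to compound 4 (1.01 log units; beyond the scatter), though less surely than a reversal of either measured step. Compound 4 is estimated at 300 nM, within 60 nM to 1500 nM.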

Compound 4, half-maximal inhibitory concentration: 15 nM
Beside the measured number, compound 4's estimate is 20-fold (1.30 log units) above it; the measured number lies below the stated range.
By their numbers in this assay, from the lowest: compounds 4 and 2 (each within the scatter of the next); then compound 1; then compound 3.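

In this assay, the exchange produces the largest step in this set, a 210-fold lower number from compound 3 to compound 4 (2.32 log units; beyond the scatter), and it shows that this saturated ring carbon can carry an oxygen-bearing aryl group without the weak result seen with 4-carboxyphenyl. The new group also gives an 11-fold lower number from compound 1 to compound 4 (1.03 log units; beyond the scatter), while a 1.9-fold lower number from compound 2 to compound 4 (0.29 log units; within the scatter) places compound 4 level with compound 2, so 3-(hydroxymethyl)phenyl and 4-aminophenyl cannot be told apart here. No measured information accounts for the size of these steps.

The exchange alters both the group and its place on the phenyl ring, and the compounds shown do not separate the two contributions. Also open, from the compounds shown here alone, is how a methoxymethyl group or a longer hydroxyalkyl chain would compare with hydroxymethyl.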